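Positional shift of the hydroxyl on the pendant phenyl ring

The compounds below may be only part of what the source reports. "The series", "measured", "known", "first", "only" and "open" are said of these compounds alone.

Three compounds of this series have been run in an assay on isolated protein for inhibition of Alpha glucosidase (Homo sapiens), with stated times of 5 min and 15 min; on this read-out lower numbers stand for stronger inhibition and higher numbers for weaker inhibition. Compound 1 `O=C(/C=C(O)/C=C/c1ccc(O)c(O)c1)c1ccccc1O` gives 14300 nM. Compound 2 `O=C1/C(=C/c2ccccc2)CCC/C1=C\c1ccc(F)c(F)c1` gives "not determined" (no result reported) in this assay. Among the measured compounds shown here, compound 3 `O=C1/C(=C/c2ccccc2)CCC/C1=C\c1cccc(O)c1` gives 28400 nM, the higher of the two numbers so far; compound 1 lies nearest to it, and the gap between the two falls within the usual scatter. Compound 4 `O=C1/C(=C/c2ccccc2)CCC/C1=C\c1ccc(O)cc1` has not been measured. It differs from compound 3 only by 4-hydroxyphenyl in place of 3-hydroxyphenyl on a double-bonded chain carbon bound to a double-bonded ring carbon. For the measured compounds named here, no measured step of this kind is available, so no direction is supported by the data. The expectation is a step from compound 3 to compound 4 of a 1.1-fold lower number from compound 3 to compound 4 (0.06 log units; within the scatter), that is, none beyond the scatter. Compound 4 is therefore estimated at 25000 nM, within 8000 nM to 80000 nM.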

Compound 4, half-maximal inhibitory concentration: 42300 nM
For compound 4 the middle estimate is 1.7-fold (0.23 log units) below the measured one, and the stated range covers the measured number.
By their numbers in this assay, from the lowest: compounds 1, 3 and 4 (each within the scatter of the next, the first and the last beyond it).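

This gives the series its first measured step at this position: in this assay, 4-hydroxyphenyl in place of 3-hydroxyphenyl gives a 1.5-fold higher number from compound 3 to compound 4 (0.17 log units; within the scatter). On a double-bonded chain carbon bound to a double-bonded ring carbon, the two hydroxyphenyl groups therefore cannot be told apart on this read-out. No supporting measurement bears on this result.

Still open, as far as these compounds go, is whether the hydroxyl group itself contributes to the values of compound 3 and compound 4. From the compounds shown here alone, a methoxy group or an amine on the same phenyl ring would test this, and whether either gives a number beyond the scatter of these two compounds remains unknown.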